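Shifting One Hydroxyl Group Changes Cytotoxic Potency

The source may report more compounds than this note shows. Statements on the series, on what has been measured and on what is new or still open speak of the compounds shown alone.

Measured so far in a functional assay on HCT-15 cells (Homo sapiens) for cytotoxicity, read by CCK-8 assay; a lower number here means a stronger inhibitor, a higher number a weaker inhibitor:
Compound 1, `Oc1ccc(-c2cc(-c3cccs3)cc(-c3ccccc3O)n2)cc1`: > 50000 nM.
Compound 2, `Oc1ccc(-c2cc(-c3cccs3)cc(-c3cccc(O)c3)n2)cc1`: 1770 nM.
Compound 3, `Oc1ccccc1-c1cc(-c2ccoc2)cc(-c2ccccc2O)n1`: > 50000 nM.

The value of compound 1 is a limit of the assay, not a number. The value of compound 3 is likewise only a limit. Both sit at the limit of > 50000 nM in this assay, at which 2 of the 3 values shown sit. Compound 2 differs from compound 1 by one change, (3-hydroxyphenyl in place of 2-hydroxyphenyl on an aromatic carbon), and that step is an at least 28-fold lower number from compound 1 to compound 2 (1.45 log units; beyond the scatter). Compound 4, `Oc1cccc(-c2cc(-c3ccoc3)cc(-c3ccccc3O)n2)c1`, is not yet measured; it differs from compound 3 by 3-hydroxyphenyl in place of 2-hydroxyphenyl on an aromatic carbon. This is the same kind of change, though the surroundings differ: in compound 1 the place is meta to a 4-hydroxyphenyl group and meta to a thiophen-2-yl group, in compound 3 meta to a 2-hydroxyphenyl group and meta to a furan-3-yl group. The difference between the two cores is not broken down here. The expectation for compound 4 rests on the step of an at least 28-fold lower number from compound 1 to compound 2 (1.45 log units; beyond the scatter). Compound 4 is expected to give about 8000 nM, between 1500 nM and 50000 nM, the expected step being an at least 6.2-fold lower number from compound 3 to compound 4 (0.79 log units; beyond the scatter).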

Compound 4, half-maximal inhibitory concentration: > 50000 nM
Compound 4: only a limit was reported (the forecaster's own chance of this, stated with the estimate: 35%); middle value at least 6.2-fold (0.79 log units) from the limit.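

Compound 3 and compound 4 are both reported only as limits of the assay, so the step between them cannot be read: the limit of > 50000 nM in this assay, at which 3 of the 4 values shown sit.

The compounds shown leave open whether 3-hydroxyphenyl in place of 2-hydroxyphenyl changes the number in this assay on the core of compound 3 at all.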